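The source may hold more compounds than are shown below. What is called first, only, known or untested is meant among the compounds shown, and "the series" means these compounds.

Values in an ADME assay on HEp-2 cells (Homo sapiens) for cytotoxicity; on this read-out higher numbers stand for lower toxicity in this test and lower numbers for higher toxicity in this test:
- compound 1 `CC(C)CCn1c(Cn2c(=O)n(C(C)C)c3ccccc32)nc2cc(CNC3CC3)ccc21`: 17200 nM
- compound 2 `CC(C)CCn1c(Cn2c(=O)n(C(C)C)c3ccccc32)nc2cc(CNS(C)(=O)=O)ccc21`: 30800 nM
- compound 3 `C=Cc1ccc2c(c1)nc(Cn1c(=O)n(C(C)C)c3ccccc31)n2CCC(C)C`: 6520 nM

Compound 3, at 6520 nM, has the lowest number of the three, with compound 1 nearest to it and compound 2 furthest. The next analogue, compound 4 `CC(C)CCn1c(Cn2c(=O)n(C(C)C)c3ccccc32)nc2cc(-c3nn[nH]n3)ccc21`, has 2H-tetrazol-5-yl in place of vinyl on an aromatic carbon of the six-membered aromatic ring of carbon only: 2H-tetrazol-5-yl in place of vinyl on an aromatic carbon.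

For the measured compounds named here, two measured steps bear directly on this change, since both end in the vinyl group at that same place. Putting vinyl there gave a 2.6-fold lower number from compound 1 to compound 3 (0.42 log units; beyond the scatter) and a 4.7-fold lower number from compound 2 to compound 3 (0.67 log units; beyond the scatter). The two groups it replaced, (cyclopropylamino)methyl and (methanesulfonamido)methyl, are separated by only a 1.8-fold higher number from compound 1 to compound 2 (0.25 log units; within the scatter). Going by the values given here, in these three compounds, then, vinyl goes with the lowest number in this assay, and no compound goes against that. Among the compounds with values here, no measured compound carries 2H-tetrazol-5-yl, however, so the transfer to compound 4 is uncertain. A modest rise is expected when vinyl leaves, similar in size to the two measured steps but opposite in direction. The expected change is a 3.8-fold higher number from compound 3 to compound 4 (0.58 log units; beyond the scatter). For compound 4 the estimated value is 25000 nM, with an expected range from 9000 nM to 80000 nM.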

Compound 4, half-maximal cytotoxic concentration: 2000 nM
Compound 4: the middle estimate sits 13-fold (1.10 log units) above what was measured, outside the stated range (below it).
By their numbers in this assay, from the lowest: compound 4; then compound 3; then compounds 1 and 2 (each within the scatter of the next).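

In this assay, vinyl did not mark the low end at this aromatic carbon, since 2H-tetrazol-5-yl in its place gave a 3.3-fold lower number from compound 3 to compound 4 (0.51 log units; beyond the scatter) and so moved the number further down, not back up. Measured against the two groups with a substituted aminomethyl chain, the change is larger still: an 8.6-fold lower number from compound 1 to compound 4 (0.93 log units; beyond the scatter) for (cyclopropylamino)methyl and a 15-fold lower number from compound 2 to compound 4 (1.19 log units; beyond the scatter) for (methanesulfonamido)methyl, the latter being the largest step in the set. Vinyl has no hydrogen-bond donors or acceptors and 2H-tetrazol-5-yl has both, yet these two groups give the two lowest numbers, so across these four compounds such counts alone do not order the results at this position.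

No measurement on hand says why 2H-tetrazol-5-yl gives the lowest number of the four. On these data alone, it also remains open whether the low number follows the tetrazole ring itself or its attachment straight to the aromatic carbon, which a (2H-tetrazol-5-yl)methyl group could separate, and whether a carboxylic acid or a primary amine at the same place would fall near compound 4 or near compound 2 in this test.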